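Swapping Bromo for Chloro on the Shared Core

The source may report more compounds than this note shows. Statements on the series, on what has been measured and on what is new or still open speak of the compounds shown alone.

Compound 1 `Brc1ccc(OCCOc2nc3ccccc3s2)c(Br)c1` gives 87.3% in a functional assay on the whole organism with Mus musculus as the target, with a stated time of 1 h, at a dose of 100 mg/kg by the intraperitoneal route; on this read-out higher numbers stand for more inhibition at the one dose given (going by the name of the read-out) and lower numbers for less inhibition.
Compound 2 `Brc1ccc(OCCOc2nc3ccccc3s2)cc1` gives 94.6% in this assay.
Compound 3 `FC(F)(F)c1ccc(COc2nc3ccccc3s2)cc1` gives 12.2% in this assay.

Of the three numbers shown, compound 2 has the highest, though compound 1 sits within the scatter of it (a number 7.3 percentage points higher from compound 1 to compound 2 (within the scatter)), while compound 3 lies far lower, beyond the scatter. The change to compound 4 `Clc1ccc(OCCOc2nc3ccccc3s2)cc1` is chloro in place of bromo on an aromatic carbon. Within the data shown here, the one measured step that bears on this is a number 7.3 percentage points higher from compound 1 to compound 2 (within the scatter), which removed a bromo rather than exchanging it and stayed within the scatter. Exchanging one halogen for another is therefore expected to shift the number little, giving an estimated step of a number 8.6 percentage points lower from compound 2 to compound 4 (within the scatter). Compound 4 is expected to give 86% in this assay, within a range from 65% to 98%.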

Compound 4, a percentage reported as inhibition, in the whole organism at one dose (the size of the read-out at that dose, not a potency): 66.3%
Estimate against measurement, compound 4: 19.7 percentage points above; the range from low to high includes it.
By their numbers in this assay, from the lowest: compound 3; then compound 4; then compounds 1 and 2 (each within the scatter of the next).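

In this assay, the group on this aromatic carbon, para to a large group, matters even when one halogen replaces another: chloro in place of bromo gives a number 28.3 percentage points lower from compound 2 to compound 4 (beyond the scatter). The other listed step, a number 7.3 percentage points higher from compound 1 to compound 2 (within the scatter), stayed within the scatter, so this exchange is the first single change here to move the number beyond it. No measurement shown accounts for the drop. Still open, from the compounds shown here alone, is how fluoro, a methoxy group or an amine at this same place would compare with bromo and chloro.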